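From 2,5-dichlorobenzyl to propyl on the sulfur

The source may report more compounds than this note shows. Statements on the series, on what has been measured and on what is new or still open speak of the compounds shown alone.

Compound 1 `Cc1cc(N2CC[C@@H](C)[C@@H](N(C)c3ncnc4[nH]ccc34)C2)n2nc(SCc3ccccc3)nc2n1` gives 67200 nM
Compound 2 `Cc1cc(N2CC[C@@H](C)[C@@H](N(C)c3ncnc4[nH]ccc34)C2)n2nc(SCc3ccc(Cl)cc3)nc2n1` gives > 100000 nM as a limit of the assay
Compound 3 `Cc1cc(N2CC[C@@H](C)[C@@H](N(C)c3ncnc4[nH]ccc34)C2)n2nc(SCc3cc(Cl)ccc3Cl)nc2n1` gives 87500 nM

In a toxicity assay on GES1 cells (Homo sapiens) for inhibition, read by MTT assay, with a stated time of 72 h (a higher number here means a weaker inhibitor, a lower number a stronger inhibitor), compound 3 gives 87500 nM and sits within the scatter of compound 1 (67200 nM). The value of compound 2 is a limit. Compound 4 `CCCSc1nc2nc(C)cc(N3CC[C@@H](C)[C@@H](N(C)c4ncnc5[nH]ccc45)C3)n2n1` puts ethyl in place of 2,5-dichlorophenyl on a saturated chain carbon bound to a sulfur. The measured steps only add chloro to that ring: neither an at least 1.4-fold higher number from compound 1 to compound 2 (0.17 log units; that floor lies within the scatter) nor a 1.3-fold higher number from compound 1 to compound 3 (0.11 log units; within the scatter) shows a change beyond the scatter. Among the compounds with values here, no measured compound lacks the ring, so this is an extrapolation. In this assay the expected step (a 1.1-fold lower number from compound 3 to compound 4 (0.04 log units; within the scatter)) is none beyond the scatter. For compound 4 the estimated value is 80000 nM with an expected range from 40000 nM to 160000 nM in this assay.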

Compound 4, half-maximal inhibitory concentration: 67100 nM
Compound 4: the middle estimate sits 1.2-fold (0.08 log units) above what was measured; the range from low to high includes it.
By their numbers in this assay, from the lowest: compounds 4, 1 and 3 (each within the scatter of the next). At a limit, above all of these: compound 2.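

Going from 2,5-dichlorobenzyl to propyl on the sulfur removes the aromatic ring altogether, yet this assay shows a 1.3-fold lower number from compound 3 to compound 4 (0.12 log units; within the scatter), and the ring without chloro gives a 1.0-fold lower number from compound 1 to compound 4 (0.00 log units; within the scatter). The earlier steps shown here only added chloro to that ring; these show that the ring itself can go with no change beyond the scatter. The step of an at least 1.4-fold lower number from compound 2 to compound 4 (0.17 log units; that floor lies within the scatter) rests on a limit of the assay and gives only a floor: the limit of > 100000 nM in this assay, at which 1 of the 4 values shown sits.

As far as these compounds go, whether any group at this position moves the number beyond the scatter stays open. An amine, a carboxylic acid or a longer chain on the sulfur would test that.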